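A few compounds are considered here, and "the series" means these few. Any claim that something is new, unique, unknown or untested is made for them only; others in the source may bear on it.

Series notes. The shared core runs unchanged through the three measured compounds; they differ only in the aryl group on an aromatic nitrogen. Compound 1 `Cc1ccccc1-n1nncc1CN1C(=O)C2(C(C#N)=C(N)Oc3c(N)cc4nc5ccccc5nc4c32)c2ccccc21` carries 2-methylphenyl, and in a functional assay on A549 cells (Homo sapiens) for antiproliferative activity, read by MTT assay, with a stated time of 48 h (on this read-out higher numbers stand for weaker inhibition and lower numbers for stronger inhibition), compound 1 gives 31700 nM. Compound 2 `CCOc1ccc(-n2nncc2CN2C(=O)C3(C(C#N)=C(N)Oc4c(N)cc5nc6ccccc6nc5c43)c3ccccc32)cc1` carries 4-ethoxyphenyl; in this assay compound 2 returns only a limit of the assay, > 50000 nM, not a number. Compound 3 `N#CC1=C(N)Oc2c(N)cc3nc4ccccc4nc3c2C12C(=O)N(Cc1cnnn1-c1ccc(Cl)cc1Cl)c1ccccc12` carries 2,4-dichlorophenyl; in this assay compound 3 likewise returns only a limit, > 50000 nM. Compound 3 thus stands at the limit, as does compound 2, while compound 1 alone returns a number. From the compounds shown here alone, the steps from compound 1 read an at least 1.5-fold higher number from compound 1 to compound 2 (0.19 log units; that floor lies within the scatter) and an at least 1.5-fold higher number from compound 1 to compound 3 (0.19 log units; that floor lies within the scatter); their floors fall within the scatter and, with the limit of > 50000 nM in this assay, at which 2 of the 3 values shown sit, their true size stays open. Between the two limits the step is unreadable: a step that the two limits leave unreadable from compound 2 to compound 3.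

Compound 4 `N#CC1=C(N)Oc2c(N)cc3nc4ccccc4nc3c2C12C(=O)N(Cc1cnnn1-c1c(Cl)cc(Cl)cc1Cl)c1ccccc12` is the next member. The change: chloro in place of hydrogen on an aromatic carbon, so the ring goes from 2,4-dichlorophenyl to 2,4,6-trichlorophenyl. The steps bearing on it are the aryl swaps from compound 1 and the unreadable step between the two limits; none gives a readable size for this chloro. No step beyond the scatter is therefore expected in this assay, and compound 4 is expected to sit at or near the limit again, a step that the limit leaves unreadable from compound 3 to compound 4 being the expected step. The estimate for compound 4 is 60000 nM, range 20000 nM to 200000 nM.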

Compound 4, half-maximal inhibitory concentration: > 50000 nM
Compound 4 was reported as a limit (the forecaster's own chance of this, stated with the estimate: 70%); the middle value lies beyond the limit too.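

In this assay a further chloro on the aryl group of compound 3, ortho to a large group, brings no number back, and the steps to compound 4 from compound 2 and from compound 3 cannot be read. Going by these compounds alone, the only readable step is an at least 1.5-fold higher number from compound 1 to compound 4 (0.19 log units; that floor lies within the scatter) and it gives a floor only, so the 2,4,6-trichlorophenyl group cannot be sized against the 2-methylphenyl group and compound 1 remains the sole compound with a number. What compound 4 adds is a third aryl group at the limit, now with chloro on both positions ortho to the bond to the aromatic nitrogen, so that the limit holds for most of the series: the limit of > 50000 nM in this assay, at which 3 of the 4 values shown sit.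

From the compounds shown here alone, whether this chloro changes antiproliferative activity at all stays open, as does any ordering among compound 2, compound 3 and compound 4. How an unsubstituted phenyl, or an amine or a carboxylic acid placed on this aryl ring, would read in this assay is open as well.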